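Changing the Aryl Group on an Arylamino Quinone Core

The source may hold more compounds than are shown below. What is called first, only, known or untested is meant among the compounds shown, and "the series" means these compounds.

Measured compounds:
Compound 1, `Cc1ccc(NC2=CC(=O)c3c(nc4n3[C@H]3OC[C@@H](O)[C@H]3OC4)C2=O)cc1C`: in a functional assay on HeLa cells (Homo sapiens) for inhibition, read by sulforhodamine B assay (a higher number here means a weaker inhibitor, a lower number a stronger inhibitor), compound 1 gives 4320 nM.
Compound 2, `O=C1C(N2CCCC2)=CC(=O)c2c1nc1n2[C@H]2OC[C@@H](O)[C@H]2OC1`: compound 2 gives only a limit of the assay, > 16000 nM.
Compound 3, `O=C1C(N2CCCCC2)=CC(=O)c2c1nc1n2[C@H]2OC[C@@H](O)[C@H]2OC1`: compound 3 likewise gives only a limit, > 16000 nM.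

For the measured compounds named here, compound 1 stands alone as the only actual number in this assay; the other two values are limits, as noted in the limit of > 16000 nM in this assay, at which 2 of the 3 values shown sit. Replacing its (3,4-dimethylphenyl)amino group by pyrrolidin-1-yl gave an at least 3.7-fold higher number from compound 1 to compound 2 (0.56 log units; beyond the scatter), and by piperidin-1-yl gave an at least 3.7-fold higher number from compound 1 to compound 3 (0.56 log units; beyond the scatter). The step between compound 2 and compound 3 cannot be read, since both sit at the limit.

Compound 4, `CCOc1ccccc1NC1=CC(=O)c2c(nc3n2[C@H]2OC[C@@H](O)[C@H]2OC3)C1=O`, changes only the aryl part of the amino group: 2-ethoxyphenyl in place of 3,4-dimethylphenyl on an amine nitrogen. Going by the values given here, both measured steps removed the whole arylamino group, so neither bears directly on this change; they show only that keeping an arylamino group is what gave compound 1 its number. Since compound 4 keeps that group, the expectation is a step within the scatter, a 1.2-fold higher number from compound 1 to compound 4 (0.06 log units; within the scatter). Compound 4 is therefore estimated at 5000 nM, with a range from 1500 nM to 16000 nM.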

Compound 4, half-maximal inhibitory concentration: 8300 nM
Beside the measured number, compound 4's estimate is 1.7-fold (0.22 log units) below it; low and high end bracket the measured number.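

In this assay, replacing 3,4-dimethylphenyl on the amine nitrogen with 2-ethoxyphenyl, which carries an oxygen the first group lacks, gives a 1.9-fold higher number from compound 1 to compound 4 (0.28 log units; within the scatter) and so no change that can be told apart from the scatter. Compound 4 is the second compound here with an arylamino group to give an actual number, so that result now holds for two different aryl groups, while compound 2 and compound 3, which lack such a group, give only limits of the assay. No measurement shown explains why the two aryl groups read alike.

The compounds shown leave open how an unsubstituted phenyl ring or a pyridine ring on the same nitrogen would read. They also leave open whether an aryl group carrying an amine or a carboxylic acid would keep a measurable number in this assay.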